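Amide-side aryl change in a shared-core series

This account rests on a few compounds, and the source may have more. Where it says the series, first, only, none or still open, it means among the compounds named here.

Compound 3 `Cn1nccc1C(=O)NCc1ccc(CNS(=O)(=O)c2ccc3c(c2)CCO3)cc1` gives 40% in an assay on cells for inhibition of C-X-C chemokine receptor type 4 (Homo sapiens), with a stated time of 22 h, tested at 100 nM; on this read-out higher numbers stand for more inhibition at the one concentration tested (going by the name of the read-out) and lower numbers for less inhibition. Compound 1 `O=C(NCc1ccc(CNS(=O)(=O)c2ccc3c(c2)CCO3)cc1)c1cccc2c1COC2` gives 40% and compound 2 `O=C(NCc1ccc(CNS(=O)(=O)c2ccccc2F)cc1)c1cc2ccccn2n1` gives 40%; all three values stand level with one another within the scatter, so compound 3 is neither set apart from compound 1 nor from compound 2 on this read-out.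

Compound 4 `O=C(NCc1ccc(CNS(=O)(=O)c2ccc3c(c2)CCO3)cc1)c1cc2ccccn2n1` differs from compound 3 in one place: a group of 9 heavy atoms (7 carbon, 2 nitrogen; one five-membered aromatic ring with 2 hetero atoms, one six-membered aromatic ring with 1 hetero atom) in place of a group of 6 heavy atoms (4 carbon, 2 nitrogen; one five-membered aromatic ring with 2 hetero atoms), on a carbonyl carbon. The group entering compound 4 is the same group that compound 2 carries on its carbonyl carbon, while the remainder of compound 4 matches compound 3 and compound 1.

For the measured compounds named here, the only measured step that bears on the change is no change at the digits printed from compound 1 to compound 3 (within the scatter), where the group of 9 heavy atoms with one five-membered non-aromatic ring and one six-membered aromatic ring gave way to the 1-methyl-1H-pyrazol-5-yl group without a shift beyond the scatter. Compound 2 and compound 3 are also level, so the two amide-side groups that meet in the present change have both sat at the same level in this assay. A step of no change at the digits printed from compound 3 to compound 4 (within the scatter) is therefore expected, that is, none beyond the scatter. Compound 4 is estimated at 40%, within 28% to 52%.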

Compound 4, a percentage reported as inhibition, at one concentration (the size of the read-out at that concentration, not a potency): 40%
For compound 4 middle estimate and measured number coincide at the digits printed, within the range that was stated.
By their numbers in this assay, from the lowest: compounds 1, 2, 3 and 4 (each within the scatter of the next).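

On the carbonyl carbon, the group with one five-membered and one six-membered aromatic ring in place of 1-methyl-1H-pyrazol-5-yl gives no change at the digits printed from compound 3 to compound 4 (within the scatter) in this assay, and the same group in place of the amide-side group of compound 1 gives no change at the digits printed from compound 1 to compound 4 (within the scatter), so three different amide-side groups on one sulfonyl side now read level. The sulfonyl sulfur also gains its first single-place comparison: with that amide-side group held fixed, the group with a five-membered non-aromatic ring and a six-membered carbon ring in place of the fluorine-bearing six-membered carbon ring gives no change at the digits printed from compound 2 to compound 4 (within the scatter). Nothing on hand offers an explanation for this level reading at either place.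

With all four compounds level at the one concentration of this read-out, the compounds shown leave open whether any change at the carbonyl carbon or the sulfonyl sulfur moves the value beyond the scatter, and whether these four would separate in a full concentration series. From the compounds shown here alone, it also remains open whether a different kind of group on the carbonyl carbon, such as an aminomethyl chain or a benzoic acid ring, would depart from this level.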